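This account rests on a few compounds, and the source may have more. Where it says the series, first, only, none or still open, it means among the compounds named here.

Measured so far:
Compound 1, `Cn1ncc2c(-c3ccccc3)cc(NNC(=O)Nc3cc(Cl)nc(Cl)c3)nc21`: 1020 nM
Compound 2, `Cc1nn(C)c2nc(NNC(=O)Nc3cc(Cl)nc(Cl)c3)cc(C3CC3)c12`: 3650 nM
Compound 3, `Cc1cc(NNC(=O)Nc2cc(Cl)nc(Cl)c2)nc2c1c(C)nn2C`: 11000 nM

In an assay on isolated protein for binding affinity to sphingosine 1-phosphate receptor 2 (Homo sapiens), read by surface plasmon resonance (on this read-out higher numbers stand for weaker binding and lower numbers for tighter binding), compound 3 gives the highest of the three numbers; compound 2 stands nearest, and compound 1 furthest, with the lowest number of the set.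

Compound 4, `Cc1nn(C)c2nc(NNC(=O)Nc3cc(Cl)nc(Cl)c3)cc(-c3ccccc3)c12`, has not yet been measured. It differs from compound 3 in one place: phenyl in place of methyl on an aromatic carbon.

Among the measured compounds shown here, one measured step bears on this change. Going a 3.0-fold higher number from compound 2 to compound 3 (0.48 log units; beyond the scatter), so putting a smaller group at that position of the shared core gave a modestly higher number. Compound 4 goes the other way, to a larger group, and compound 1, which also carries a phenyl on its core, gives 1020 nM, a lower number than compound 3. A modest move to a lower number is therefore expected for compound 4, estimated as a 7.3-fold lower number from compound 3 to compound 4 (0.87 log units; beyond the scatter) in this assay. Compound 4 is expected to give about 1500 nM, most likely between 500 nM and 4500 nM.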

Compound 4, dissociation constant: 5320 nM
Estimate against measurement, compound 4: 3.5-fold (0.55 log units) below; measured number outside the range, above it.
By their numbers in this assay, from the lowest: compound 1; then compounds 2 and 4 (each within the scatter of the next); then compound 3.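

In this assay, phenyl in place of methyl gives a 2.1-fold lower number from compound 3 to compound 4 (0.32 log units; beyond the scatter), so the larger group does lower the number at this position, though only modestly. Phenyl in place of cyclopropyl gives a 1.5-fold higher number from compound 2 to compound 4 (0.16 log units; within the scatter), so these two groups cannot be told apart here, and going larger than cyclopropyl shows no further gain. Methyl in place of hydrogen on an aromatic carbon gives a 5.2-fold higher number from compound 1 to compound 4 (0.72 log units; beyond the scatter), which shows that a phenyl does not bring the low number of compound 1 when that other carbon carries a methyl.

No measurement shown here explains the size of any of these steps. Going by these compounds, it also remains open how an amine or a longer chain would fare opposite the ring nitrogen, and how cyclopropyl would fare with hydrogen in place of the methyl.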